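Adding a Second Fluoro Group: Expected Maximal Response

A few compounds are considered here, and "the series" means these few. Any claim that something is new, unique, unknown or untested is made for them only; others in the source may bear on it.

Compound 1, `O=C1C=C(Nc2ccccc2)C(=O)c2cnccc21`, measured in a functional assay on the whole organism (aorta) with Rattus norvegicus as the target; a higher number here means a larger maximal response, a lower number a smaller maximal response: 93%
Compound 2, `O=C1C=C(Nc2cccc(F)c2)C(=O)c2cnccc21`, in this assay: 89%

Compound 2 gives the lower of the two numbers, but its nearest neighbour is compound 1, and the step of a number 4 percentage points lower from compound 1 to compound 2 (within the scatter). So the two values are not distinguishable from each other.

Compound 3, `O=C1C=C(Nc2cc(F)cc(F)c2)C(=O)c2cnccc21`, has not yet been measured. Compared with compound 2 it carries the change (fluoro in place of hydrogen on an aromatic carbon). This is the same kind of change that took compound 1 to compound 2, repeated on the other side of the same ring. Among the measured compounds shown here, the only step that bears on it, a number 4 percentage points lower from compound 1 to compound 2 (within the scatter), stayed within the scatter, so no shift beyond the scatter in this assay is expected; if anything a small easing is expected, a number 4 percentage points lower from compound 2 to compound 3 (within the scatter). For compound 3 the estimated value is 85%, with a range from 72% to 96%.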

Compound 3, largest response reached (Emax), in percent of the reference or control that the assay uses: 94%
Estimate against measurement, compound 3: 9 percentage points below; measured number inside the range.
By their numbers in this assay, from the lowest: compounds 2, 1 and 3 (each within the scatter of the next).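

Placing a fluoro group meta to a fluoro group on the six-membered aromatic ring gives a number 5 percentage points higher from compound 2 to compound 3 (within the scatter) in this assay, so the second fluoro group leaves the maximal response indistinguishable from that of compound 2. The first replacement of this kind, a number 4 percentage points lower from compound 1 to compound 2 (within the scatter), gave the same reading, and the two steps now show that this change can be made twice in the series without a shift beyond the scatter. This place therefore accepts a fluoro group in this assay whether or not the ring already carries one. Going by these compounds, whether a methoxy group, an amine or a trifluoromethyl group at this place would move the response beyond the scatter remains open. No measured property of these compounds is available to explain this result.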